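The compounds below may be only part of what the source reports. "The series", "measured", "known", "first", "only" and "open" are said of these compounds alone.

Compound 3, `O=C(COc1ccc2cc(C(O)(C(F)(F)F)C(F)(F)F)c(O)cc2c1)NCc1ccccc1`, stands at the weak end of this small set: in an assay on isolated protein for inhibition of tyrosine-protein phosphatase non-receptor type 13 (Homo sapiens), read by spectrophotometry (a lower number here means a stronger inhibitor, a higher number a weaker inhibitor), compound 3 gives > 20000 nM, a limit of the assay rather than a number. Compound 1, `CCN(CC)C(=O)COc1ccc2cc(C(O)(C(F)(F)F)C(F)(F)F)c(O)cc2c1`, likewise gives > 20000 nM, which is also a limit. For the measured compounds named here, compound 2, `Cc1ccc(S(=O)(=O)NNC(=O)COc2ccc3cc(C(O)(C(F)(F)F)C(F)(F)F)c(O)cc3c2)cc1`, is the only one with a number, giving 14900 nM. The measured steps are small or unreadable: an at least 1.3-fold lower number from compound 1 to compound 2 (0.12 log units; that floor lies within the scatter), an at least 1.3-fold higher number from compound 2 to compound 3 (0.12 log units; that floor lies within the scatter), and a step that the two limits leave unreadable from compound 1 to compound 3, owing to the limit of > 20000 nM in this assay, at which 2 of the 3 values shown sit. Compound 4, `O=C(COc1ccc2cc(C(O)(C(F)(F)F)C(F)(F)F)c(O)cc2c1)Nc1ccc(-c2ccccc2)cc1`, differs from compound 3 in one place: 4-phenylphenyl in place of benzyl on an amide-type nitrogen. Since every change at this amide-type nitrogen so far has left potency weak, no step beyond the scatter is expected, and compound 4 is estimated at 20000 nM (from 7000 nM to 60000 nM), a change of a number no higher from compound 3 to compound 4 (the limit leaves the size open).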

Compound 4, half-maximal inhibitory concentration: 2800 nM
Compound 4: the middle estimate sits 7.1-fold (0.85 log units) above what was measured; measured number outside the range, below it.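

At this amide-type nitrogen, the choice of group does change the result in this assay: 4-phenylphenyl in place of benzyl gives an at least 7.1-fold lower number from compound 3 to compound 4 (0.85 log units; beyond the scatter), and 4-phenylphenyl in place of ((4-methylphenyl)sulfonyl)amino gives a 5.3-fold lower number from compound 2 to compound 4 (0.73 log units; beyond the scatter). For the compounds shown here, these are the first steps at this position that lie beyond the scatter. The first is only a floor, and its true size cannot be read: the limit of > 20000 nM in this assay, at which 2 of the 4 values shown sit.

On these data alone, it remains open whether the gain comes from the second aromatic ring or from the ring sitting directly on the nitrogen, without the benzyl carbon. A plain phenyl group on this nitrogen would separate the two.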